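Fluoro for chloro on a diaminotriazine-bearing aryl ring

This account rests on a few compounds, and the source may have more. Where it says the series, first, only, none or still open, it means among the compounds named here.

Measured compounds:
compound 1, `Nc1nc(N)nc(-c2cc(Br)ccc2F)n1`: 100%
compound 2, `Nc1nc(N)nc(-c2cc(Br)ccc2Cl)n1`: 86%
compound 3, `Nc1nc(N)nc(-c2cc(Cl)ccc2Br)n1`: 81%

Three compounds share a core and differ only in the halogens on the aryl ring. In a functional assay on the whole organism with Rattus norvegicus as the target, at a dose of 20 mg/kg by the intraperitoneal route (on this read-out higher numbers stand for more inhibition at the one dose given (going by the name of the read-out) and lower numbers for less inhibition), compound 1 gives 100%, compound 2 gives 86% and compound 3 gives 81%. The values of compound 2 and compound 3 lie within the scatter of each other, whereas compound 1 stands apart from both of them.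

One change is seen once in the measured set: fluoro in place of chloro on an aromatic carbon. It made a step of a number 14 percentage points higher from compound 2 to compound 1 (beyond the scatter).

The difference between the cores of compound 2 and compound 3 is not broken down here; the two have the same atoms joined differently.

Compound 4, `Nc1nc(N)nc(-c2cc(F)ccc2Br)n1`, has not been measured in this assay. It stands to compound 3 as compound 1 stands to compound 2: fluoro in place of chloro on an aromatic carbon. The change is the same kind, not the same. In the measured pair the site is ortho to a group of 8 heavy atoms; in the pair with compound 4 it is meta to a group of 8 heavy atoms; in both it is para to a bromo group.

Among the measured compounds shown here, for compound 4 in this assay a step of a number 12 percentage points higher from compound 3 to compound 4 (beyond the scatter) is expected, resting on the one measured step of a number 14 percentage points higher from compound 2 to compound 1 (beyond the scatter) and on the value of compound 3, 81%. Compound 4 is therefore estimated at 93%, between 80% and 100%.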

Compound 4, a percentage reported as inhibition, in the whole organism at one dose (the size of the read-out at that dose, not a potency): 78%
Compound 4: middle estimate off by 15 percentage points, on the high side; the measured number lies below the stated range.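

On the core of compound 3, fluoro in place of chloro on an aromatic carbon, meta to a group of 8 heavy atoms and para to a bromo group, gave a number 3 percentage points lower from compound 3 to compound 4 (within the scatter) in this assay, so the gain seen on the other pair did not carry across to this one. Set side by side, the two instances of the same change do not agree: the same change on two cores in this assay, a number 14 percentage points higher (beyond the scatter) from compound 2 to compound 1 and a number 3 percentage points lower (within the scatter) from compound 3 to compound 4, 17 percentage points apart, beyond the scatter of two such steps. Among the compounds shown here, this shows that, in this series, the step measured on one pair cannot be added as a fixed increment to a compound with the halogens placed differently, but with only two pairs it does not show which step is the more typical, nor why they part, and a read-out at a single dose says nothing about potency.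

The compounds shown carry only halogens on the aryl ring, which leaves open how a methyl group, a methoxy group or an amine would behave at these same places and whether such groups would respond alike on both arrangements. Also open, going by these compounds, is whether the pattern would hold if the amino groups of the shared core were replaced, for example by a methylamino group.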